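Homologating the Piperidine Ether Side Chain

This account rests on a few compounds, and the source may have more. Where it says the series, first, only, none or still open, it means among the compounds named here.

Compound 3 `Clc1ccc(OCc2nc3c(OCCC4CCCNC4)cccc3n2CCCC2CCCNC2)cc1` gives 18 nM in an assay on isolated protein for binding affinity to Neuropeptide Y receptor type 1 (Homo sapiens) (a lower number here means a stronger inhibitor, a higher number a weaker inhibitor), the second highest number among the three measured compounds. Compound 1 `Clc1ccc(OCc2nc3c(OCCC4CCNCC4)cccc3n2CCCC2CCCNC2)cc1` gives 7 nM in this assay, and compound 2 `Clc1ccc(OCc2nc3ccccc3n2CCCC2CCNCC2)cc1`, which lacks the ether side chain altogether, gives 980 nM. Among the measured compounds shown here, the only measured step that bears on the next change is a 2.6-fold higher number from compound 1 to compound 3 (0.41 log units; beyond the scatter). Compound 4 `Clc1ccc(OCc2nc3c(OCCCC4CCNCC4)cccc3n2CCCC2CCCNC2)cc1` carries (piperidin-4-yl)methyl in place of piperidin-3-yl on a saturated chain carbon, two bonds along the chain from an oxygen on an aromatic ring. Attachment through piperidin-4-yl returns to the arrangement of compound 1, while the added methylene has no measured counterpart among these compounds. Compound 4 is therefore expected to show a step of a 1.8-fold lower number from compound 3 to compound 4 (0.26 log units; within the scatter), a move toward a lower number. On this basis compound 4 is estimated at 10 nM, within a range from 3 nM to 40 nM.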

Compound 4, inhibition constant: 152 nM
Estimate against measurement, compound 4: 15-fold (1.18 log units) below, and the stated range ends below it.
By their numbers in this assay, from the lowest: compound 1; then compound 3; then compound 4; then compound 2.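

At this place, on a saturated chain carbon two bonds along the chain from an oxygen on an aromatic ring, the longer link is poorly tolerated: (piperidin-4-yl)methyl in place of piperidin-4-yl gives a 22-fold higher number from compound 1 to compound 4 (1.34 log units; beyond the scatter) in this assay. Restoring the piperidin-4-yl attachment does not make up for the extra methylene, since the change from piperidin-3-yl to (piperidin-4-yl)methyl still gives an 8.4-fold higher number from compound 3 to compound 4 (0.93 log units; beyond the scatter) in the same assay. No available evidence accounts for this loss. Going by these compounds, whether (piperidin-3-yl)methyl at this place would fare better remains open, as does the effect of a pyrrolidin-3-yl ring on the shorter chain.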